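Ring-nitrogen substitution in the piperazine series

The source may report more compounds than this note shows. Statements on the series, on what has been measured and on what is new or still open speak of the compounds shown alone.

Measured so far:
compound 1 `NC(=O)C(c1ccccc1)N1CCN(CCCc2c[nH]c3ccc(-n4cnnc4)cc23)CC1` 0.2 nM
compound 2 `c1cc2[nH]cc(CCCN3CCNCC3)c2cc1-n1cnnc1` 31 nM

In an assay on CHO cells for displacement of a labelled ligand from 5-hydroxytryptamine receptor 1D (Homo sapiens) (on this read-out lower numbers stand for stronger inhibition and higher numbers for weaker inhibition), compound 2 gives the highest of the two numbers; the only other point, compound 1, sits far lower. Compound 3 `CN1CCN(CCCc2c[nH]c3ccc(-n4cnnc4)cc23)CC1` carries methyl in place of hydrogen on an amine nitrogen in a ring. Among the measured compounds shown here, the one step that bears on this position, a 160-fold higher number from compound 1 to compound 2 (2.19 log units; beyond the scatter), shows that a large group on this ring nitrogen matters greatly. A methyl is far smaller, so only part of that gain is expected, as a 3.1-fold lower number from compound 2 to compound 3 (0.49 log units; beyond the scatter). Compound 3 is therefore estimated at 10 nM, range 3 nM to 40 nM.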

Compound 3, half-maximal inhibitory concentration: 33 nM
Beside the measured number, compound 3's estimate is 3.3-fold (0.52 log units) below it; measured number inside the range.
By their numbers in this assay, from the lowest: compound 1; then compounds 2 and 3 (each within the scatter of the next).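

In this assay, methyl in place of hydrogen on this ring nitrogen leaves the number unmoved (a 1.1-fold higher number from compound 2 to compound 3 (0.03 log units; within the scatter)), so a single carbon does not recover any of the level of compound 1. The gap remains large with methyl (a 170-fold higher number from compound 1 to compound 3 (2.22 log units; beyond the scatter)), so among these compounds the low number goes with carbamoyl(phenyl)methyl, not with substitution at this nitrogen as such. No available evidence explains this result.

Open, on these data alone, is whether the phenyl or the carbamoyl part carries the step, which benzyl or carbamoylmethyl on this nitrogen would separate. Also open, as far as these compounds go, is how much of the step a longer chain, such as propyl, would show.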